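Removing one chain carbon from the oxime of compound 2

The source may hold more compounds than are shown below. What is called first, only, known or untested is meant among the compounds shown, and "the series" means these compounds.

Measured compounds:
compound 1 `CC(=C\c1cccc([N+](=O)[O-])c1)/C(C)=N/O` — "not determined" (no result reported)
compound 2 `CC(/C=C/c1ccc(Cl)cc1)=N\O` — 27600 nM

Within the data shown here, compound 1 carries no number, so compound 2 is the only compound with a measured value. In a functional assay on HEK293 cells for agonist activity at transient receptor potential cation channel subfamily A member 1 (Homo sapiens), read by scintillation counting and calcium flux (on this read-out higher numbers stand for an effect only at larger amounts of compound and lower numbers for an effect already at smaller amounts), compound 2 gives 27600 nM, and with nothing else measured there is no way to say whether that is strong or weak within this small set; it simply stands alone.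

Compound 3 `O/N=C\C=C\c1ccc(Cl)cc1` has not yet been measured. The change from compound 2 to compound 3 is a group of 3 heavy atoms (1 carbon, 1 nitrogen, 1 oxygen; no ring) in place of a group of 4 heavy atoms (2 carbon, 1 nitrogen, 1 oxygen; no ring), on a double-bonded chain carbon bound to a double-bonded chain carbon. The shared core, the ring and the double-bonded chain are kept; only the group on a double-bonded chain carbon bound to a double-bonded chain carbon is exchanged for a smaller one.

Among the measured compounds shown here, no step between two measured compounds is available to guide the size of the change. With compound 2 as the only anchor, compound 3 is expected to stay close to it, and the estimated step of a 1.1-fold higher number from compound 2 to compound 3 (0.04 log units; within the scatter) is expected to lie within the usual scatter. For compound 3 the estimate is 30000 nM, with a range from 10000 nM to 90000 nM.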

Compound 3, half-maximal effective concentration: 9400 nM
Compound 3: the middle estimate sits 3.2-fold (0.50 log units) above what was measured; the whole stated range lies above it.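

Among these compounds, the result gives the first reading of this position: in this assay, a group of 3 heavy atoms in place of a group of 4 heavy atoms, on a double-bonded chain carbon bound to a double-bonded chain carbon, comes with a 2.9-fold lower number from compound 2 to compound 3 (0.47 log units; beyond the scatter). The two groups match in their counts of hydrogen-bond donors and acceptors and differ in holding 1 carbon rather than 2 carbon, so the position responds to an exchange this small, and the smaller group is the one that acts at smaller amounts of compound, though this is a modest step that rests on a single pair. Nothing at hand explains the direction of this step.

The compounds shown leave open whether the trend continues in the other direction, with a longer chain at this place, or whether the oxime can give way to a different group altogether, such as an amine or a carboxylic acid. They also leave open whether the same exchange would give a step of similar size on a ring that carries something other than the chlorine of compound 2 and compound 3.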